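Aryl exchange at the end of compound 3

The source may hold more compounds than are shown below. What is called first, only, known or untested is meant among the compounds shown, and "the series" means these compounds.

In a functional assay on SW-620 cells (Homo sapiens) for inhibition, read by MTT assay, with a stated time of 72 h (on this read-out lower numbers stand for stronger inhibition and higher numbers for weaker inhibition), compound 1 `COc1cc(NC(C)CCCNC(=O)Nc2ccc(Br)cc2)c2ncccc2c1` gives 23000 nM and compound 2 `COc1cc(NC(C)CCCNC(=O)Nc2cccc(O)c2)c2ncccc2c1` gives 27000 nM on the same read-out. In this assay compound 3 `COc1cc(NC(C)CCCNC(=O)NNC(=O)Nc2cccc(C(F)(F)F)c2)c2ncccc2c1` gives 21000 nM and so stands level with the other two, within the scatter.

Compound 4 `COc1cc(NC(C)CCCNC(=O)NNC(=O)Nc2ccc(O)cc2)c2ncccc2c1` has not yet been measured. The change from compound 3 is 4-hydroxyphenyl in place of 3-(trifluoromethyl)phenyl on an amide-type nitrogen and amounts to 4-hydroxyphenyl in place of 3-(trifluoromethyl)phenyl on an amide-type nitrogen.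

Among the measured compounds shown here, the one measured step of a similar kind is a 1.2-fold higher number from compound 1 to compound 2 (0.07 log units; within the scatter) and stays within the scatter, with 3-hydroxyphenyl in place of 4-bromophenyl on an amide-type nitrogen. For the measured compounds named here, that step was taken on the chain shared by compound 1 and compound 2, not on the chain of compound 3, and no measured compound carries 4-hydroxyphenyl, so it serves only as a guide. Going by the values given here, compound 2, the only measured compound with a hydroxyl on its aryl group, gives 27000 nM and lies within the scatter of compound 3.

No step beyond the scatter is therefore expected in this assay, and the estimated step is a 1.1-fold higher number from compound 3 to compound 4 (0.04 log units; within the scatter) with no firm direction. Compound 4 is expected at 23000 nM within an estimated range of 11000 nM to 48000 nM for now.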

Compound 4, half-maximal inhibitory concentration: > 100000 nM
Compound 4 ended at the assay's limit (the forecaster's own chance of this, stated with the estimate: 10%); at least 4.3-fold (0.63 log units) between middle value and limit.
By their numbers in this assay, from the lowest: compounds 3, 1 and 2 (each within the scatter of the next). At a limit, above all of these: compound 4.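

In this assay the aryl group on this amide-type nitrogen is not interchangeable: 4-hydroxyphenyl in place of 3-(trifluoromethyl)phenyl gives an at least 4.7-fold higher number from compound 3 to compound 4 (0.67 log units; beyond the scatter), whereas the earlier aryl exchange gave only a 1.2-fold higher number from compound 1 to compound 2 (0.07 log units; within the scatter). The group ((4-hydroxyphenyl)carbamoyl)amino also separates from the simple aryl groups on the same nitrogen, with an at least 3.7-fold higher number from compound 2 to compound 4 (0.56 log units; beyond the scatter) and an at least 4.3-fold higher number from compound 1 to compound 4 (0.63 log units; beyond the scatter), so the series now holds a change that reaches beyond the scatter. The value of compound 4 is a limit of the assay, so these steps give only a lower bound on size: the limit of > 100000 nM in this assay, at which 1 of the 4 values shown sits.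

Compound 3 and compound 4 differ in the whole aryl group, so the compounds shown do not separate the loss of the trifluoromethyl group from the gain of the hydroxyl or from the place of that hydroxyl on the ring. A methoxy group, an amine or a carboxylic acid on the aryl ring of this chain, or a trifluoromethyl group on the shorter chain of compound 1, would help to show which part of the change carries the step.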